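Swapping Acetamido for Hydroxy on a Side Chain

A few compounds are considered here, and "the series" means these few. Any claim that something is new, unique, unknown or untested is made for them only; others in the source may bear on it.

Measured compounds:
compound 1 `O=C(N[C@@H]1CNCC[C@H]1c1ccc(Cl)cc1)c1ccc(-c2ncnc3c2CCC3O)s1`: 23000 nM
compound 2 `CC(=O)NCC[C@@H]1C[C@@H](c2ccc(F)c(F)c2)[C@H](NC(=O)c2cc(-c3c(Cl)cnn3C)c(Cl)o2)CN1`: 920 nM

In a functional assay on HCT-116 cells (Homo sapiens) for antiproliferative activity, read by sulforhodamine B assay, with a stated time of 72 h (on this read-out higher numbers stand for weaker inhibition and lower numbers for stronger inhibition), compound 1 gives 23000 nM. Compound 2 gives 920 nM, the lowest of the two numbers shown, and its gap to compound 1 lies beyond the usual scatter. Compound 3 `Cn1ncc(Cl)c1-c1cc(C(=O)N[C@@H]2CN[C@H](CCO)C[C@H]2c2ccc(F)c(F)c2)oc1Cl` differs from compound 2 by one change: hydroxy in place of acetamido on a saturated chain carbon, two bonds along the chain from a saturated ring carbon. Among the measured compounds shown here, no measured pair shows this kind of change, so the expected step from compound 2 to compound 3 is a 1.0-fold lower number from compound 2 to compound 3 (0.01 log units; within the scatter), a shift not expected to go beyond the scatter in either direction. Compound 3 is therefore estimated at 900 nM, within a range of 300 nM to 3000 nM.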

Compound 3, half-maximal inhibitory concentration: 360 nM
Beside the measured number, compound 3's estimate is 2.5-fold (0.40 log units) above it; low and high end bracket the measured number.
By their numbers in this assay, from the lowest: compound 3; then compound 2; then compound 1.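

Among the compounds shown here, this is the first measured change at this position: in this assay, hydroxy in place of acetamido gives a 2.6-fold lower number from compound 2 to compound 3 (0.41 log units; beyond the scatter). The 2-acetamidoethyl group is therefore not needed for this level of activity, and the shorter 2-hydroxyethyl group does better in this one pair. Nothing available here explains the shift.

As far as these compounds go, it remains open how an amine or a carboxylic acid would compare at this place, and whether a longer chain ending in hydroxy would lower the number further. This single pair also cannot show whether the same swap would give a similar step on another core.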